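The source may report more compounds than this note shows. Statements on the series, on what has been measured and on what is new or still open speak of the compounds shown alone.

Compound 1 `CNc1nc(-c2cc(OC)c(OC)c(OC)c2)c(-c2ccc(C)cc2)s1` is the strongest of the three measured compounds: in a functional assay on Jurkat cells (Homo sapiens) for antiproliferative activity, read by MTT assay, with a stated time of 72 h (a lower number here means a stronger inhibitor, a higher number a weaker inhibitor), compound 1 gives 19 nM. Compound 2 `CNc1nc(-c2cc(OC)c(OC)c(OC)c2)c(-c2ccc(C(F)(F)F)cc2)s1` differs from it by trifluoromethyl in place of methyl on an aromatic carbon, and in this assay compound 2 gives 3010 nM, a step of a 160-fold higher number from compound 1 to compound 2 (2.20 log units; beyond the scatter). Compound 3 `COc1cc(-c2nc(C)sc2-c2ccc(C)cc2)cc(OC)c1OC` has a different core, differing from compound 1 by methyl in place of methylamino on an aromatic carbon; in this assay compound 3 gives 517 nM, a step of a 27-fold higher number from compound 1 to compound 3 (1.43 log units; beyond the scatter). Compound 4 `COc1cc(-c2nc(C)sc2-c2ccc(C(F)(F)F)cc2)cc(OC)c1OC` has not yet been measured. It differs from compound 3 by trifluoromethyl in place of methyl on an aromatic carbon, the same change that separates compound 1 and compound 2, at the same place. For compound 4 a large step of a 58-fold higher number from compound 3 to compound 4 (1.76 log units; beyond the scatter) is expected in this assay, because the same change gave a 160-fold higher number from compound 1 to compound 2 (2.20 log units; beyond the scatter). Compound 4 is therefore estimated at about 30000 nM in this assay, plausibly between 5000 nM and 150000 nM, with a fair chance that only a limit is reported.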

Compound 4, half-maximal inhibitory concentration: 7110 nM
Compound 4: middle estimate off by 4.2-fold (0.63 log units), on the high side, within the range that was stated.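

On the core of compound 3, trifluoromethyl in place of methyl again gives a weaker compound in this assay, with a 14-fold higher number from compound 3 to compound 4 (1.14 log units; beyond the scatter), so the direction carries over but the size does not: the same change on two cores in this assay, a 160-fold higher number (2.20 log units; beyond the scatter) from compound 1 to compound 2 and a 14-fold higher number (1.14 log units; beyond the scatter) from compound 3 to compound 4, 12-fold (1.06 log units) apart, beyond the scatter of two such steps
Methyl in place of methylamino also gives a weaker compound when trifluoromethyl is present, with a 2.4-fold higher number from compound 2 to compound 4 (0.37 log units; beyond the scatter), and this step also differs in size from its earlier counterpart: the same change on two cores in this assay, a 27-fold higher number (1.43 log units; beyond the scatter) from compound 1 to compound 3 and a 2.4-fold higher number (0.37 log units; beyond the scatter) from compound 2 to compound 4, 12-fold (1.06 log units) apart, beyond the scatter of two such steps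
These four compounds show that the direction held on both cores and that the effects of the two changes do not simply add up, but they do not show why the sizes differ or what would happen on any other core.

On these data alone, it remains open how a chlorine atom would behave in place of trifluoromethyl, or how a plain amine would behave in place of methylamino.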